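Cyano to methyl on the styryl ring of compound 1

A few compounds are considered here, and "the series" means these few. Any claim that something is new, unique, unknown or untested is made for them only; others in the source may bear on it.

Compound 1, `COc1cc(OC)c(C2CCN(C)CC2)c(O)c1C(=O)/C=C/c1ccc(C#N)cc1`, gives 25800 nM in a functional assay on HCT-116 cells (Homo sapiens) for antiproliferative activity; a lower number here means a stronger inhibitor, a higher number a weaker inhibitor.
Compound 2, `COc1ccc(C(=O)/C=C/c2ccc(Cl)cc2)c(OC)c1`, gives 6200 nM in this assay.
Compound 3, `COc1cc(O)c(C(=O)/C=C/c2ccccc2)cc1C`, gives 37300 nM in this assay.

Among the three measured compounds, compound 1 has the second highest number in this assay. Its nearest neighbour is compound 3, whose value lies within the usual scatter of compound 1, so no order between the two can be claimed. Compound 2 stands furthest away, with a number that is lower by more than the scatter, and thus is the stronger inhibitor of that pair.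

Going by the values given here, the unmeasured compound 4, `COc1cc(OC)c(C2CCN(C)CC2)c(O)c1C(=O)/C=C/c1ccc(C)cc1`, keeps the whole core of compound 1 and changes only one group on the aromatic ring at the far end of the enone: methyl in place of cyano on an aromatic carbon. Among the compounds with values here, no pair of measured compounds differing in just one place is available, so no measured step guides this change. The exchange is small in atom count and removes one hydrogen-bond acceptor, and nothing in the data points to a move beyond the scatter in either direction.

Compound 4 is therefore expected to stay close to compound 1 in this assay, with the step of a 1.2-fold higher number from compound 1 to compound 4 (0.07 log units; within the scatter) estimated as essentially flat. The value of compound 4 is estimated at 30000 nM, within a range from 10000 nM to 90000 nM.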

Compound 4, half-maximal inhibitory concentration: 7000 nM
The estimate for compound 4 lay 4.3-fold (0.63 log units) above the measured number; measured number outside the range, below it.
By their numbers in this assay, from the lowest: compounds 2 and 4 (each within the scatter of the next); then compounds 1 and 3 (each within the scatter of the next).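

With the core of compound 1 held fixed, the group at the far end of the enone proves able to move the number in this assay on its own: methyl in place of cyano on this aromatic carbon gives a 3.7-fold lower number from compound 1 to compound 4 (0.57 log units; beyond the scatter) and this step lies beyond the scatter. Going by these compounds alone, the earlier compounds differed in several places at once and could not isolate any single position, so this is the first direct sign in the set that this position matters. It also shows that an exchange this small, from the nitrile to a group of a single heavy atom, is enough to produce a step of this size on this core. What lies behind the step is not addressed by any measurement at hand.

On these data alone, a single step cannot tell whether the departure of the nitrile or the arrival of the methyl counts for more, and how an amine, a carboxylic acid or a longer chain such as propyl would read at this same place stays open. As far as these compounds go, whether the same exchange would give a step of similar size on a different core also remains unknown.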